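The source may report more compounds than this note shows. Statements on the series, on what has been measured and on what is new or still open speak of the compounds shown alone.

Of the compounds shown here, three that share one core have been tested in an ADME assay on HEL cells (Homo sapiens) for cytotoxicity; a lower number here means that less compound is tolerated, a higher number that more compound is tolerated. Compound 1 `Cc1ccc(-[n+]2noc([O-])c2CN2CCN(C)CC2)cc1` gives 100 ug/mL in this assay. Compound 2 `Cc1ccc(-[n+]2noc([O-])c2CN2CCNCC2)cc1`, which carries hydrogen in place of methyl on an amine nitrogen in a ring, gives 100 ug/mL. Compound 3 `CC(=O)N1CCN(Cc2c([O-])on[n+]2-c2ccc(C)cc2)CC1`, which carries acetyl in place of methyl on an amine nitrogen in a ring, gives 100 ug/mL, so compound 3 stands level with compound 1 and compound 2 on the digits shown. The three steps among them, no change at the digits printed from compound 1 to compound 2 (within the scatter), no change at the digits printed from compound 1 to compound 3 (within the scatter) and no change at the digits printed from compound 2 to compound 3 (within the scatter), all stay within the scatter of the assay. Compound 4 `Cc1ccc(-[n+]2noc([O-])c2CN2CCN(c3ccccc3)CC2)cc1` differs from compound 3 by phenyl in place of acetyl on an amine nitrogen in a ring. Every measured exchange at this ring nitrogen, whether to hydrogen, methyl or acetyl, left the read-out unchanged, so a phenyl there is expected to move it little as well. The expected step is no change at the digits printed from compound 3 to compound 4 (within the scatter). Compound 4 is therefore estimated at 100 ug/mL, with a range from 50 ug/mL to 200 ug/mL.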

Compound 4, minimum cytotoxic concentration: 100 ug/mL
Compound 4: the middle estimate sits on the measured number at the digits printed; the measured number falls inside the stated range.
By their numbers in this assay, from the lowest: compounds 1, 2, 3 and 4 (each within the scatter of the next).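

Phenyl is the first aromatic ring on this ring nitrogen and, at six heavy atoms, is larger than the three-atom acetyl it replaces. Even so, this assay gives no change at the digits printed from compound 3 to compound 4 (within the scatter) and the comparisons with the smaller groups give no change at the digits printed from compound 2 to compound 4 (within the scatter) and no change at the digits printed from compound 1 to compound 4 (within the scatter) with no sign of a shift. The read-out therefore stays level across hydrogen, methyl, acetyl and phenyl, with no compound here going against that pattern, though nothing available gives a reason for it.

From the compounds shown here alone, it remains open whether a carboxylic acid, a primary amine or a longer chain on this nitrogen would also stay level. The rest of the shared core is the same in all four compounds, so the effect of a change there cannot be told from these results.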